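Adrenergic antagonist series: trifluoromethyl in place of cyclopropylmethoxy

This account rests on a few compounds, and the source may have more. Where it says the series, first, only, none or still open, it means among the compounds named here.

Two compounds of the series carry a number in a functional assay for antagonist activity at Alpha-1A adrenergic receptor (Oryctolagus cuniculus); a lower number here means tighter binding, a higher number weaker binding. Compound 1 `COc1ccccc1N1CCN(CCCNc2ncccc2C(=O)C2CC2)CC1` gives 0.501 nM in this assay. Compound 2 `CN(C)C(=O)c1cccnc1NCCCN1CCN(c2ccccc2OCC2CC2)CC1` gives 0.159 nM in this assay, the lower of the two numbers; compound 1 stands a step above it that lies beyond the scatter. Compound 3 `CN(C)C(=O)c1cccnc1NCCCN1CCN(c2ccccc2C(F)(F)F)CC1` has not yet been measured. It differs from compound 2 in one place: trifluoromethyl in place of cyclopropylmethoxy on an aromatic carbon. The cyclopropylmethoxy group leaves, the trifluoromethyl group enters, on an aromatic carbon of a six-membered aromatic ring of carbon only, ortho to a large group. Going by the values given here, no pair of measured compounds shows this change, so its size has no precedent. A moderate weakening is expected from compound 2 to compound 3, a 3.1-fold higher number from compound 2 to compound 3 (0.50 log units; beyond the scatter), with the outcome uncertain in both directions. Compound 3 is therefore estimated at 0.5 nM in this assay, within a range from 0.15 nM to 2 nM.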

Compound 3, dissociation constant: 12.6 nM
The estimate for compound 3 lay 25-fold (1.40 log units) below the measured number, outside the stated range (above it).
By their numbers in this assay, from the lowest: compound 2; then compound 1; then compound 3.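

In this assay, going by these compounds alone, this place on the aromatic ring is far from indifferent to its group: trifluoromethyl in place of cyclopropylmethoxy gives a 79-fold higher number from compound 2 to compound 3 (1.90 log units; beyond the scatter), the first step to show how much the number depends on this position. The leaving group brings a three-membered ring and a hydrogen-bond acceptor, the entering group neither, and this single step cannot separate the two differences. Nothing measured on these compounds speaks to the origin of the step.

Still open, going by these compounds, is whether the ether oxygen, the cyclopropyl ring or the trifluoromethyl group itself sets the size of the step. A methoxy group, an ethoxy group or a chlorine atom at this place on the core of compound 2 would help to separate these readings.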